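The source may report more compounds than this note shows. Statements on the series, on what has been measured and on what is new or still open speak of the compounds shown alone.

Measured in a functional assay on MOLT-4 cells (Homo sapiens) for cytotoxicity, read by CCK-8 assay, with a stated time of 24 h; on this read-out lower numbers stand for stronger inhibition and higher numbers for weaker inhibition:
- compound 1 `C=CC(=O)N1C(=O)CC(C)Sc2ccccc21` gives 730000 nM
- compound 2 `C=CC(=O)N1C(=O)CC(c2ccc(Br)cc2)Sc2ccccc21` gives 106000 nM
- compound 3 `C=CC(=O)N1C(=O)CCSc2ccccc21` gives 565000 nM

Compound 3 stands in the upper pair of these three numbers. Its partner in that pair is not separated from it, with a 1.3-fold lower number from compound 1 to compound 3 (0.11 log units; within the scatter) on record, while the remaining compound lies clearly lower, with a 5.3-fold higher number from compound 2 to compound 3 (0.73 log units; beyond the scatter) on record.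

Compound 4 `C=CC(=O)N1C(=O)CC(c2cccc(Cl)c2)Sc2ccccc21` carries 3-chlorophenyl in place of hydrogen on a saturated ring carbon, next to the ring sulfur (3-chlorophenyl in place of hydrogen on a saturated ring carbon).

For the measured compounds named here, two measured steps bear on this change. Going by the values given here, compound 2 is the only measured compound with a phenyl ring on this carbon, and it supplies the closest precedent, seen again as a 6.9-fold lower number from compound 1 to compound 2 (0.84 log units; beyond the scatter) against the methyl group. Among the compounds with values here, that precedent carries a 4-bromophenyl group, so no measurement yet covers 3-chlorophenyl, and the size of the step remains uncertain. A modest move to a lower number in this assay is therefore expected, similar in size to the step seen with compound 2 and opposite in direction to a 5.3-fold higher number from compound 2 to compound 3 (0.73 log units; beyond the scatter). The expected step is a 4.3-fold lower number from compound 3 to compound 4 (0.64 log units; beyond the scatter). Compound 4 is estimated at 130000 nM, with an expected range from 55000 nM to 320000 nM.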

Compound 4, half-maximal inhibitory concentration: 77500 nM
Beside the measured number, compound 4's estimate is 1.7-fold (0.22 log units) above it; the measured number falls inside the stated range.
By their numbers in this assay, from the lowest: compounds 4 and 2 (each within the scatter of the next); then compounds 3 and 1 (each within the scatter of the next).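

In this assay, a second aryl group on the saturated ring carbon next to the ring sulfur again gives a lower number than the unsubstituted carbon (a 7.3-fold lower number from compound 3 to compound 4 (0.86 log units; beyond the scatter)) and than the methyl group (a 9.4-fold lower number from compound 1 to compound 4 (0.97 log units; beyond the scatter)). The two halogen-bearing aryl groups are not separated (a 1.4-fold lower number from compound 2 to compound 4 (0.14 log units; within the scatter)), so exchanging 4-bromophenyl for 3-chlorophenyl, which alters both the halogen and its place on the phenyl ring, has no readable effect here. Across these four compounds, the lower numbers therefore go with a halogen-bearing phenyl ring on this carbon rather than with one particular halogen or substitution pattern, but no supporting data explain this link.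

Whether the halogen contributes at all remains open, since the compounds shown include no unsubstituted phenyl group on this carbon. Also open, from the compounds shown here alone, is how this position responds to a longer alkyl chain, an amine or a carboxylic acid, and whether the aryl step holds when the vinylcarbonyl group on the ring nitrogen is replaced by a simple acetyl group.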